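Putting an amino group back: expected clearance

The source may report more compounds than this note shows. Statements on the series, on what has been measured and on what is new or still open speak of the compounds shown alone.

compound 1 `NCCOc1ccc([C@H]2CC[C@]3(CC2)OOC2(O3)C3CC4CC(C3)CC2C4)cc1` gives < 7 mL.min-1.g-1 (a limit of the assay, not a number)
compound 2 `CS(=O)(=O)N1CCN(CCCOc2ccc([C@H]3CC[C@]4(CC3)OOC3(O4)C4CC5CC(C4)CC3C5)cc2)CC1` gives 68 mL.min-1.g-1 (a measured number)

Going by the values given here, in an ADME assay on microsomes from liver (Homo sapiens) for metabolic stability, read by LC-MS, tested at 1 uM (on this read-out lower numbers stand for slow clearance and higher numbers for fast clearance), compound 2 gives 68 mL.min-1.g-1 (the only actual number so far). Compound 3 `NCCS(=O)(=O)CCOc1ccc([C@H]2CC[C@]3(CC2)OOC2(O3)C3CC4CC(C3)CC2C4)cc1` has not yet been measured. It differs from compound 2 by a single exchange ((2-aminoethyl)sulfonyl in place of (4-(methylsulfonyl)piperazin-1-yl)methyl on a saturated chain carbon, two bonds along the chain from an oxygen on an aromatic ring). Among the compounds with values here, one measured step bears on this exchange: an at least 9.7-fold higher number from compound 1 to compound 2 (0.98 log units; beyond the scatter) (there, the (4-(methylsulfonyl)piperazin-1-yl)methyl group took the place of amino). Compound 3 loses that group and, like compound 1, carries an amino group again, so a clear fall is expected. Within the data shown here, only this one step supports that expectation, and the sulfonyl part is untested, so the fall may be smaller. The expected change is a 5.7-fold lower number from compound 2 to compound 3 (0.75 log units; beyond the scatter) (an estimate). Compound 3 is estimated at 12 mL.min-1.g-1 (expected range 5 mL.min-1.g-1 to 35 mL.min-1.g-1).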

Compound 3, intrinsic clearance in microsomes: 9 mL.min-1.g-1
The estimate for compound 3 lay 1.3-fold (0.12 log units) above the measured number; measured number inside the range.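

In this assay, a second exchange on a saturated chain carbon, two bonds along the chain from an oxygen on an aromatic ring, gives a 7.6-fold lower number from compound 2 to compound 3 (0.88 log units; beyond the scatter). Both the leaving and the entering group contain a sulfonyl, so in these compounds a sulfonyl does not by itself go with a high clearance number, as compound 3 keeps its sulfonyl and still reads low. Against compound 1 only a floor can be read, an at least 1.2-fold higher number from compound 1 to compound 3 (0.10 log units; that floor lies within the scatter), and no order between the two can be claimed, because the comparison rests on a limit and not on a number: the limit of < 7 mL.min-1.g-1 in this assay, at which 1 of the 3 values shown sits.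

From the compounds shown here alone, it stays open whether the amino group or the loss of the six-membered ring goes with the lower number. A carboxylic acid or a methylsulfonyl at the same place, in place of (2-aminoethyl)sulfonyl, would help to separate the two.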